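A Methyl Branch on the Propyl Chain of Compound 3

The compounds below may be only part of what the source reports. "The series", "measured", "known", "first", "only" and "open" are said of these compounds alone.

Of the compounds shown here, three on a shared core have been measured in an assay on membranes from HeLa cells for displacement of a labelled ligand from adenosine receptor A3 (Homo sapiens), read by scintillation counting, with a stated time of 180 min, tested at 1 uM; on this read-out higher numbers stand for more inhibition at the one concentration tested (going by the name of the read-out) and lower numbers for less inhibition. Compound 3 `CCCC(=O)C1=C(C)NC(=O)NC1c1ccoc1` stands lowest: in this assay compound 3 gives 2%. Compound 1 `CC1=C(C(=O)OCC(C)C)C(c2ccoc2)NC(=O)N1` gives 16%, and compound 2 `CC1=C(C(=O)C2CC2)C(c2ccoc2)NC(=O)N1` gives 16%. The two measured steps that lead to compound 3 are both modest and both downward: a number 14 percentage points lower from compound 1 to compound 3 (beyond the scatter), and a number 14 percentage points lower from compound 2 to compound 3 (beyond the scatter). Between the other two, no change at the digits printed from compound 1 to compound 2 (within the scatter).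

Compound 4 `CC1=C(C(=O)CC(C)C)C(c2ccoc2)NC(=O)N1` differs from compound 3 in one place: methyl in place of hydrogen on a saturated chain carbon bound to two saturated chain carbons. Among the compounds with values here, none of the measured steps adds a methyl to a chain in this way; the steps on record swap the whole group on the carbonyl carbon rather than branch it. What they show is that the propyl ketone of compound 3 sits at the bottom of this small set, while the two alternatives at the same carbonyl carbon both read about the same and somewhat higher. The isobutyl that enters is named alongside the isobutoxy of compound 1, which is the higher of the two. A small rise, at the edge of the scatter, is therefore expected; it is not expected to exceed the modest size of the measured steps. Compound 4 is estimated at 9%, with a range from 0% to 22%. The expected step is a number 7 percentage points higher from compound 3 to compound 4 (within the scatter).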

Compound 4, a percentage reported as inhibition, at one concentration (the size of the read-out at that concentration, not a potency): 18%
Estimate against measurement, compound 4: 9 percentage points below, and the stated range covers the measured number.
By their numbers in this assay, from the lowest: compound 3; then compounds 1, 2 and 4 (each within the scatter of the next).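

Adding one methyl to the propyl chain, on a saturated chain carbon bound to two saturated chain carbons, gives in this assay a number 16 percentage points higher from compound 3 to compound 4 (beyond the scatter), which shows that this branch alone, with the ketone kept, can move the reading beyond the scatter. The isobutyl group does not open a new level at the carbonyl carbon: the comparisons give a number 2 percentage points higher from compound 2 to compound 4 (within the scatter) and a number 2 percentage points higher from compound 1 to compound 4 (within the scatter), so isobutyl, cyclopropyl and isobutoxy cannot be told apart here, and among these four compounds only the propyl ketone of compound 3 stands apart from the rest. No supporting measurement bears on why the branch has this effect on the reading.

The compounds shown leave open whether the rise depends on the branch itself or would also come with a longer unbranched chain such as butyl, and whether a neopentyl group at the same carbonyl carbon would read any differently. They also leave open how these differences at a single concentration relate to potency, and whether the methyl step would hold on a core other than the shared one.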